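The source may hold more compounds than are shown below. What is called first, only, known or untested is meant among the compounds shown, and "the series" means these compounds.

In an ADME assay on L02 cells (Homo sapiens) for inhibition, read by CCK-8 assay, with a stated time of 48 h (on this read-out lower numbers stand for stronger inhibition of growth and higher numbers for weaker inhibition of growth), compound 1 `Cc1ccc(CNc2nc(Nc3ccc(N4CCN(C)CC4)cn3)ncc2Cl)cc1` gives > 100000 nM as a limit of the assay, not a number. Compound 2 `COc1ccc(CNc2nc(Nc3ccc(N4CCN(C)CC4)cn3)ncc2Cl)cc1` gives 12900 nM in this assay. Compound 3 `Cc1ccc(Nc2nc(Nc3ccc(N4CCN(C)CC4)cn3)ncc2Cl)cc1` gives 13900 nM and stands within the scatter of compound 2, as a 1.1-fold higher number from compound 2 to compound 3 (0.03 log units; within the scatter) records. Next comes compound 4 `COc1ccc(Nc2nc(Nc3ccc(N4CCN(C)CC4)cn3)ncc2Cl)cc1`, with methoxy in place of methyl on an aromatic carbon, para to a large group (methoxy in place of methyl on an aromatic carbon). One measured step carries the same swap: an at least 7.7-fold lower number from compound 1 to compound 2 (0.88 log units; beyond the scatter), which is only a bound, resting on the limit (the limit of > 100000 nM in this assay, at which 1 of the 3 values shown sits). The step of an at least 7.1-fold lower number from compound 1 to compound 3 (0.85 log units; beyond the scatter) rests on that limit too. A smaller step in the same direction is expected in this assay, estimated as a 2.3-fold lower number from compound 3 to compound 4 (0.36 log units; beyond the scatter), with wide uncertainty. For compound 4 the estimated value is 6000 nM, with an expected range from 1800 nM to 20000 nM.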

Compound 4, concentration for 50% growth inhibition: 3150 nM
Beside the measured number, compound 4's estimate is 1.9-fold (0.28 log units) above it; the range from low to high includes it.
By their numbers in this assay, from the lowest: compound 4; then compounds 2 and 3 (each within the scatter of the next). At a limit, above all of these: compound 1.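

Methoxy in place of methyl, para to a large group, now has a measured size free of any limit, a 4.4-fold lower number from compound 3 to compound 4 (0.64 log units; beyond the scatter). With methoxy held on the ring, 4-methoxyphenyl in place of 4-methoxybenzyl also counts, a 4.1-fold lower number from compound 2 to compound 4 (0.61 log units; beyond the scatter), a direction the methyl pair showed only as a bound. The step of an at least 31-fold lower number from compound 1 to compound 4 (1.50 log units; beyond the scatter) is likewise only a bound, as compound 1 stands at a limit of the assay.

Still open, going by these compounds, is whether the swap has one size on both cores: the same change on two cores in this assay, an at least 7.7-fold lower number (0.88 log units; beyond the scatter) from compound 1 to compound 2 and a 4.4-fold lower number (0.64 log units; beyond the scatter) from compound 3 to compound 4; the limit leaves it open whether they differ How a hydroxy group, an amine or a longer ethoxy chain would read at this position also remains open.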